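The source may hold more compounds than are shown below. What is called first, only, known or untested is meant among the compounds shown, and "the series" means these compounds.

Series notes: compound 1 `O=C1N(CCCCCCOc2ccc(Br)cc2)CCN1c1ccncc1` and compound 2 `O=C1N(CCCCCCCOc2ccc(Cl)cc2)CCN1c1ccncc1` share one core. In a functional assay on cells (Homo sapiens) for cytotoxicity (on this read-out higher numbers stand for lower toxicity in this test and lower numbers for higher toxicity in this test), compound 1 gives > 25000 nM, a limit of the assay rather than a number. In this assay compound 2 likewise gives > 25000 nM, again a limit. The step that the two limits leave unreadable from compound 1 to compound 2 is therefore unreadable; both values sit at the limit of > 25000 nM in this assay, at which 2 of the 2 values shown sit. Compound 3 `O=C1N(CCCCCCOc2ccc(-c3ccoc3)cc2)CCN1c1ccncc1` is not yet measured in this assay; it differs from compound 1 by furan-3-yl in place of bromo on an aromatic carbon. Among the compounds with values here, no measured step bears on this change, so no size or direction can be read, and compound 1 is only known to stand at the limit. Compound 3 is expected to give 25000 nM (8000 nM to 60000 nM), an expected step of a number no higher from compound 1 to compound 3 (the limit leaves the size open).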

Compound 3, half-maximal cytotoxic concentration: > 25000 nM
Compound 3 gave a limit, no number; the forecaster's own chance of this, stated with the estimate: 60%; the middle value sits exactly at the limit.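

In this assay compound 3 gives > 25000 nM, a limit, so the step from compound 1 to compound 3 cannot be read: the limit of > 25000 nM in this assay, at which 3 of the 3 values shown sit. On these data alone, whether furan-3-yl in place of bromo changes this read-out at all remains open.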